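The source may hold more compounds than are shown below. What is called first, only, known or untested is meant among the compounds shown, and "the series" means these compounds.

In a functional assay on L1210 cells (Mus musculus) for cytotoxicity (on this read-out higher numbers stand for weaker inhibition and lower numbers for stronger inhibition), compound 1 `C=C[C@]1(CO)O[C@@H](n2ccc(N)nc2=O)C[C@@H]1O` gives a measured value of 21000 nM. Compound 2 `C#C[C@]1(CO)O[C@@H](n2ccc(=O)[nH]c2=O)[C@H](O)[C@@H]1O` has no measured number in this test, only a limit, > 350000 nM. Among the measured compounds shown here, the two compounds therefore cannot be set apart by a step of known size, and no pair of measured compounds here differs in one place alone. The next structure, compound 3 `N#C[C@]1(CO)O[C@@H](n2ccc(=O)[nH]c2=O)[C@H](O)[C@@H]1O`, keeps the rest of compound 2 and carries cyano in place of ethynyl on a saturated ring carbon. The entering group brings one hydrogen-bond acceptor, and the heavy-atom count stays the same. The expectation for compound 3 rests on compound 2, whose only reading is the limit > 350000 nM. A change in this assay beyond the scatter is not expected, and no direction can be named, so the expected move is small: a step that the limit leaves unreadable from compound 2 to compound 3. A second report of a limit would fit this expectation. For compound 3 the estimated value is 400000 nM, with an expected range from 150000 nM to 1000000 nM.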

Compound 3, half-maximal inhibitory concentration: > 350000 nM
Compound 3 ended at the assay's limit; the forecaster's own chance of this, stated with the estimate: 80%; the middle value does not contradict the limit.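

Compound 3, like compound 2, is reported only as a limit, and no step between the two can be read because both sit at that limit: the limit of > 350000 nM in this assay, at which 2 of the 3 values shown sit.

The compounds shown leave open whether cyano in place of ethynyl on a saturated ring carbon changes the read-out in this assay at all.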